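Acetylating the hydroxyethyl chain of compound 1

A few compounds are considered here, and "the series" means these few. Any claim that something is new, unique, unknown or untested is made for them only; others in the source may bear on it.

Within the data shown here, compound 1 `Cn1ncc(Cl)c1-c1cc(C(=O)N[C@@H]2CN[C@H](CCO)C[C@H]2c2ccc(F)c(F)c2)oc1Cl` gives 0.98 nM in an assay for inhibition of RAC-alpha serine/threonine-protein kinase (Homo sapiens), read by HTRF, with a stated time of 1 h (on this read-out lower numbers stand for stronger inhibition and higher numbers for weaker inhibition), the lowest of the two numbers known; compound 2 `Cn1ncc(Cl)c1-c1cc(C(=O)N[C@@H]2CN[C@H](CCO)C[C@H]2c2ccc(Cl)c(Cl)c2)oc1Cl` gives 2.74 nM, and the step of a 2.8-fold higher number from compound 1 to compound 2 (0.45 log units; beyond the scatter) concerns only the halogens on the phenyl ring. Compound 3 `CC(=O)OCC[C@@H]1C[C@@H](c2ccc(F)c(F)c2)[C@H](NC(=O)c2cc(-c3c(Cl)cnn3C)c(Cl)o2)CN1` keeps the difluorophenyl and carries acetyl in place of hydrogen on an oxygen on a saturated carbon, reading hydroxy to acetoxy. Among the measured compounds shown here, no measured step bears on this change, since the single known step touches a different part of the molecule. The expected step in this assay is therefore a 1.6-fold higher number from compound 1 to compound 3 (0.21 log units; within the scatter), of no more than modest size and uncertain direction. Compound 3 is estimated at 1.6 nM, within 0.5 nM to 5 nM.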

Compound 3, half-maximal inhibitory concentration: 3.4 nM
Beside the measured number, compound 3's estimate is 2.1-fold (0.33 log units) below it; measured number inside the range.
By their numbers in this assay, from the lowest: compound 1; then compounds 2 and 3 (each within the scatter of the next).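

In this assay, turning the 2-hydroxyethyl chain into 2-acetoxyethyl gives a 3.5-fold higher number from compound 1 to compound 3 (0.54 log units; beyond the scatter), so this position responds to a change made on its oxygen. The chain is thus a second place, after the halogens on the phenyl ring, where a single change moves the number beyond the scatter, though compound 3 still reads 3.4 nM. Nothing available explains this step. On these data alone, whether the step comes from the added acetyl or from the capped hydroxy stays open, as does how an amine, a carboxylic acid or a longer chain would read here.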